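The compounds below may be only part of what the source reports. "The series", "measured", "known", "first", "only" and "open" are said of these compounds alone.

In an ADME assay on NCI-H1299 cells (Homo sapiens) for inhibition, read by sulforhodamine B assay, with a stated time of 5 days (a higher number here means a weaker inhibitor, a lower number a stronger inhibitor), compound 1 `C=CS(=O)(=O)Nc1cccc(C)c1Nc1ncc(OCc2c(Cl)c(OC)cc(OC)c2Cl)cn1` gives 8330 nM and compound 2 `COc1cc(OC)c(Cl)c(COc2cnc(Nc3c(C)cccc3NC(=O)C3CO3)nc2)c1Cl` gives 133000 nM, so compound 2 holds the higher number and is the weaker inhibitor of the pair. Compound 3 `COc1cc(OC)c(Cl)c(COc2cnc(Nc3c(C)cccc3NCC=O)nc2)c1Cl` differs from compound 2 at one place: formylmethyl in place of (oxiran-2-yl)carbonyl on a nitrogen on an aromatic ring. In short, formylmethyl stands in place of (oxiran-2-yl)carbonyl on a nitrogen on an aromatic ring. For the measured compounds named here, only one measured step bears on this change, because the same nitrogen carries the exchange in a 16-fold higher number from compound 1 to compound 2 (1.20 log units; beyond the scatter), a large step beyond the scatter. Going by the values given here, no measured compound carries formylmethyl, so that step guides only the size. A sizeable step towards a lower number is expected, since compound 2 is the higher of the two, though this is uncertain. The expected change is a 3.3-fold lower number from compound 2 to compound 3 (0.52 log units; beyond the scatter). For compound 3 the estimate is 40000 nM, with an expected range of 7000 nM to 200000 nM.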

Compound 3, half-maximal inhibitory concentration: 78400 nM
The estimate for compound 3 lay 2.0-fold (0.29 log units) below the measured number, and the stated range covers the measured number.
By their numbers in this assay, from the lowest: compound 1; then compounds 3 and 2 (each within the scatter of the next).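

In this assay, exchanging (oxiran-2-yl)carbonyl for formylmethyl on this nitrogen gives a 1.7-fold lower number from compound 2 to compound 3 (0.23 log units; within the scatter), so the two groups cannot be told apart here, although formylmethyl has fewer heavy atoms and no three-membered ring. The vinylsulfonyl compound remains separate, with a 9.4-fold higher number from compound 1 to compound 3 (0.97 log units; beyond the scatter), so two different replacements of vinylsulfonyl now both give numbers beyond the scatter of compound 1, and the large step seen earlier is no longer tied to the (oxiran-2-yl)carbonyl group alone. No supporting measurement is available to explain these results.

The compounds shown leave open whether the separation of compound 1 belongs to the vinyl part or to the sulfonyl part of its group. A methylsulfonyl or an acryloyl group on this nitrogen would address that, and a plain amine would show how the position reads without any such group.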